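The source may report more compounds than this note shows. Statements on the series, on what has been measured and on what is new or still open speak of the compounds shown alone.

Of the compounds shown here, two have been tested in an ADME assay on a cell-free system (plasma, Rattus norvegicus) for metabolic stability, read by LC-MS, with a stated time of 60 min, at 37 degrees C, tested at 50 uM; a higher number here means that more of the compound is left, a lower number that less of the compound is left. Compound 1, with the structure `C[C@@H](O)[C@H]1C(=O)N2C(C(=O)OCOC(=O)C(C)(C)C)=C(S[C@@H]3CN[C@H](C(=O)Nc4cccc(C(=O)O)c4)C3)[C@H](C)[C@H]12`, gives in this assay a reading of 0%. Compound 2, drawn as `Cc1oc(=O)oc1COC(=O)N1C[C@@H]2C[C@H]1C(=O)Nc1cccc(c1)C(=O)OC/C=C/COC(=O)C1=C(S2)[C@H](C)[C@@H]2[C@@H]([C@@H](C)O)C(=O)N12`, gives in this assay a reading of 0%. On these numbers compound 2 stands level with compound 1, and the two readings lie within the usual scatter of each other, so nothing separates them.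

Compound 3, with the structure `Cc1oc(=O)oc1COC(=O)N1C[C@@H]2C[C@H]1C(=O)Nc1cccc(c1)C(=O)OC/C=C\COC(=O)C1=C(S2)[C@H](C)[C@@H]2[C@@H]([C@@H](C)O)C(=O)N12`, is the next member. It differs from compound 2 only as follows: the two compounds have the same atoms and bonds and differ only in configuration as drawn: 1 of 7 stereo elements differ; a double bond is drawn E in compound 2 and Z in compound 3.

Among the compounds with values here, no step between measured compounds is available to calibrate such a change. Since compound 2 gives 0%, and compound 1 gives 0%, no step beyond the scatter in either direction is expected in this assay. The step from compound 2 to compound 3 is therefore expected to be about no change at the digits printed from compound 2 to compound 3 (within the scatter). Compound 3 is estimated to give 0% in this assay, within a range from 0% to 10%.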

Compound 3, percent of the compound remaining in the plasma assay: 0%
Compound 3: the middle estimate sits on the measured number at the digits printed, within the range that was stated.
By their numbers in the plasma assay, from the lowest: compounds 1, 2 and 3 (each within the scatter of the next).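

Within the data shown here, for the first time, the double bond alone is varied, and in the plasma assay going from E to Z gives no change at the digits printed from compound 2 to compound 3 (within the scatter), so the drawn geometry of this double bond leaves no mark on that read-out. In a physicochemical assay for metabolic stability, read by LC-MS, in phosphate buffer, with a stated time of 3 h, at pH 7.4, tested at 50 uM (on this read-out lower numbers stand for a less stable compound and higher numbers for a more stable compound), compound 2 gives > 95%, which is a limit of the assay. In the physicochemical assay compound 3 gives > 95%, which is also a limit of the assay.

From the compounds shown here alone, the step between the two in the physicochemical assay cannot be read, because both values are limits: the limit of > 95% in the physicochemical assay, at which 2 of the 2 values shown sit. Whether a longer chain or a saturated chain in place of the one carrying the double bond would give any other reading in the plasma assay remains open.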